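Working notes on one chain-end change in two acetyl-bearing analogues

The source may report more compounds than this note shows. Statements on the series, on what has been measured and on what is new or still open speak of the compounds shown alone.

Measured so far:
Compound 1 `CC(=O)c1cc(CC(C)O)c(OCCCCC#N)cc1O`: 6%
Compound 2 `C=CCc1cc(C(C)=O)c(O)cc1OCCCCC`: 23%

Both numbers come from an assay on isolated protein for binding affinity to leukotriene B4 receptor 1 (Homo sapiens), tested at 1 uM; on this read-out lower numbers stand for less inhibition and higher numbers for more inhibition at the one concentration tested (going by the name of the read-out). Compound 2 stands highest of the two; compound 1 lies lower by a gap beyond the scatter. Among the compounds with values here, no step between measured compounds that differ in one place is known, so nothing measured tells how a chain-end change moves this read-out.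

Compound 3 `C=CCc1cc(C(C)=O)c(O)cc1OCCCCCC(=O)NO` has not been measured in this assay. It differs from compound 2 by hydroxycarbamoyl in place of hydrogen on a saturated chain carbon, five bonds along the chain from an oxygen on an aromatic ring.

The step of a number 2 percentage points higher from compound 2 to compound 3 (within the scatter) is expected to stay within the scatter, with no clear direction. Compound 3 is estimated at 25%, in the range 5% to 50%.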

Compound 3, a percentage reported as inhibition, at one concentration (the size of the read-out at that concentration, not a potency): 28%
Estimate against measurement, compound 3: 3 percentage points below; the measured number falls inside the stated range.
By their numbers in this assay, from the lowest: compound 1; then compounds 2 and 3 (each within the scatter of the next).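

Hydroxycarbamoyl in place of hydrogen on a saturated chain carbon, five bonds along the chain from an oxygen on an aromatic ring, gives a number 5 percentage points higher from compound 2 to compound 3 (within the scatter) in this assay and leaves the two compounds indistinguishable on this read-out. This first measured step at this position shows that the chain can carry the group with no shift beyond the scatter at the one concentration tested.

Going by these compounds, whether a carboxylic acid, a primary amide or a longer chain at the same place would move the read-out beyond the scatter stays open. No measured evidence bears on this result.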